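A few compounds are considered here, and "the series" means these few. Any claim that something is new, unique, unknown or untested is made for them only; others in the source may bear on it.

Compound 1 `CC(=O)N1CCN(c2nc(=O)c3cc(C(F)(F)F)cc([N+](=O)[O-])c3s2)CC1`: 83.9 ug/mL
Compound 2 `CC(C)(C)C(=O)N1CCN(c2nc(=O)c3cc(C(F)(F)F)cc([N+](=O)[O-])c3s2)CC1`: 5.87 ug/mL

Going by the values given here, in a physicochemical assay for solubility, read by HPLC (a higher number here means a more soluble compound, a lower number a less soluble compound), compound 2 holds the lower of the two numbers measured so far, and the single measured step, a 14-fold lower number from compound 1 to compound 2 (1.16 log units; beyond the scatter), is the only guide available. Compound 3 `O=C(c1ccccc1Cl)N1CCN(c2nc(=O)c3cc(C(F)(F)F)cc([N+](=O)[O-])c3s2)CC1` differs from compound 2 by 2-chlorophenyl in place of tert-butyl on a carbonyl carbon. That earlier step showed a large fall when a larger carbon group replaced a smaller one on the same carbonyl carbon, and the present change again brings in more heavy atoms, so a further moderate fall is expected, a 2.0-fold lower number from compound 2 to compound 3 (0.29 log units; within the scatter). Compound 3 is therefore estimated at 3 ug/mL, within 0.8 ug/mL to 12 ug/mL.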

Compound 3, solubility: 8.18 ug/mL
Estimate against measurement, compound 3: 2.7-fold (0.44 log units) below; measured number inside the range.
By their numbers in this assay, from the lowest: compounds 2 and 3 (each within the scatter of the next); then compound 1.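

In this assay, 2-chlorophenyl on the carbonyl carbon in place of tert-butyl gives a 1.4-fold higher number from compound 2 to compound 3 (0.14 log units; within the scatter), so at this place the aromatic ring and the branched group cannot be told apart. Set against methyl, 2-chlorophenyl gives a 10-fold lower number from compound 1 to compound 3 (1.01 log units; beyond the scatter), a large step like the one tert-butyl gave. Nothing at hand bears on what lies behind these numbers. Still open, going by these compounds, is whether a small chain carrying an amine or a carboxylic acid on this carbonyl carbon would read nearer compound 1 or nearer compound 2, and whether plain phenyl would read like 2-chlorophenyl.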